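The compounds below may be only part of what the source reports. "The series", "measured", "known", "first", "only" and "open" are said of these compounds alone.

Compound 1 (`COc1ccc(C(=O)/C=C/c2ccc(C(=O)N3CCCC3)cc2)c(O)c1`) stands in an ADME assay on SH-SY5Y cells (Homo sapiens) for cytotoxicity, read by MTT assay, with a stated time of 48 h (a lower number here means a stronger inhibitor, a higher number a weaker inhibitor), at > 100000 nM, and this reading is a limit of the assay, not a number. Compound 2 (`CCOCCOc1cccc(/C=C/C(=O)c2ccc(OC)cc2O)c1`) reads > 100000 nM, which is likewise a limit. Among the compounds with values here, the series so far offers only (the limit of > 100000 nM in this assay, at which 2 of the 2 values shown sit). Within the data shown here, no numerical value therefore exists for compound 1, and no step between measured compounds is available to size a structural change.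

Compound 3 (`COc1ccc(C(=O)/C=C/c2ccc(C(=O)N(C)c3ccccc3)cc2)c(O)c1`) keeps the core of compound 1 and alters the amide: methyl(phenyl)amino in place of pyrrolidin-1-yl on a carbonyl carbon. In words, methyl(phenyl)amino stands in place of pyrrolidin-1-yl on a carbonyl carbon.

The expectation rests on compound 1, whose reading of > 100000 nM is a limit. The expected step of a number no higher from compound 1 to compound 3 (the limit leaves the size open) is none beyond the scatter in this assay. Any larger move is expected toward a lower number, and a further limit reading is the most likely result. Compound 3 is estimated at 100000 nM, with an expected range of 40000 nM to 200000 nM.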

Compound 3, half-maximal inhibitory concentration: > 100000 nM
Compound 3: no number, only a limit; the forecaster's own chance of this, stated with the estimate: 70%; the middle value lies on the limit itself.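

In this assay no step can be read from compound 1 to compound 3, as neither reading is a number: the limit of > 100000 nM in this assay, at which 3 of the 3 values shown sit. The compounds shown leave open how far compound 1, compound 2 and compound 3 lie from that limit, and whether any change to the shared core would give a number in this assay.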